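The source may report more compounds than this note shows. Statements on the series, on what has been measured and on what is new or still open speak of the compounds shown alone.

Among the compounds with values here, compound 1 `CCCCCCCCS(=O)(=O)Nc1cc(-c2ccc(OC)cc2)ccc1C(=O)O` was tested in an assay on mitochondria (strain BALB/c) for inhibition of glycerol-3-phosphate acyltransferase 1, mitochondrial (Mus musculus), read by scintillation counting, with a stated time of 10 min (a lower number here means a stronger inhibitor, a higher number a weaker inhibitor), where compound 1 gives 13300 nM, the lower of the two numbers so far. Compound 2 `CCCCCCCCS(=O)(=O)Nc1ccc(-c2cccc(F)c2)cc1C(=O)O` gives 37600 nM in this assay. Compound 3 `CCCCCCCCS(=O)(=O)Nc1cc(CCc2ccc(OC)cc2)ccc1C(=O)O` has not yet been measured; it differs from compound 1 by 2-(4-methoxyphenyl)ethyl in place of 4-methoxyphenyl on an aromatic carbon. Within the data shown here, no measured pair shows what such a change does here, so the direction rests on expectation alone. A modest weakening, or nothing beyond the scatter, is expected, and the expected step is a 1.5-fold higher number from compound 1 to compound 3 (0.18 log units; within the scatter). Compound 3 is estimated at 20000 nM in this assay, within a range from 5000 nM to 70000 nM.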

Compound 3, half-maximal inhibitory concentration: 43000 nM
Compound 3: the middle estimate sits 2.2-fold (0.33 log units) below what was measured, within the range that was stated.
By their numbers in this assay, from the lowest: compound 1; then compounds 2 and 3 (each within the scatter of the next).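

In this assay, 2-(4-methoxyphenyl)ethyl in place of 4-methoxyphenyl, on the aromatic carbon para to the carboxy group, gives a 3.2-fold higher number from compound 1 to compound 3 (0.51 log units; beyond the scatter). This position therefore responds to what is attached there, and inserting the ethyl link weakens inhibition rather than improving it. No measurement shown gives a reason for this weakening.

Still open, on these data alone, is how a methylene or an amide linker would compare with the ethyl link. The compounds shown also leave open whether an amine in place of the methoxy group would change the number.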